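The source may report more compounds than this note shows. Statements on the series, on what has been measured and on what is new or still open speak of the compounds shown alone.

Three compounds share one core and differ only in the group carried on a sulfur atom. Compound 1 `Cc1cc(Sc2ccccc2Cl)c(S(C)(=O)=O)cc1C(=O)N=C(N)N` carries 2-chlorophenyl there, and in a functional assay for inhibition of sodium/hydrogen exchanger (Oryctolagus cuniculus) (a higher number here means a weaker inhibitor, a lower number a stronger inhibitor), compound 1 gives 14 nM. Compound 2 `Cc1cc(Sc2ccc(Cl)cc2)c(S(C)(=O)=O)cc1C(=O)N=C(N)N` carries 4-chlorophenyl, and in this assay compound 2 gives 19 nM. Compound 3 `Cc1cc(Sc2ccccc2)c(S(C)(=O)=O)cc1C(=O)N=C(N)N` carries an unsubstituted phenyl, and in this assay compound 3 gives 14 nM. On these numbers compound 3 stands level with compound 1, the two together the lowest of the three, though all three lie within the scatter of one another: a 1.4-fold lower number from compound 2 to compound 3 (0.13 log units; within the scatter). The other measured steps are just as flat, a 1.4-fold higher number from compound 1 to compound 2 (0.13 log units; within the scatter) and no change at the digits printed from compound 1 to compound 3 (within the scatter).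

Compound 4 `COc1cc(C)c(C(=O)N=C(N)N)cc1S(C)(=O)=O` has not yet been measured. It is made from compound 3 by the change (methoxy in place of phenylsulfanyl on an aromatic carbon). For the measured compounds named here, none of the measured steps bears directly on this change: each of them exchanged one substituent on the phenyl ring for another while the phenylsulfanyl group itself stayed, and each stayed within the scatter. The present change removes that whole group and puts methoxy in its place, so the measured steps give no guide to the size or direction of the outcome. The estimated step of a 3.6-fold higher number from compound 3 to compound 4 (0.55 log units; beyond the scatter) therefore leans only slightly toward a higher number and is an expectation rather than a measurement. For compound 4 the estimate in this assay is 50 nM, with a range from 10 nM to 300 nM.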

Compound 4, half-maximal inhibitory concentration: 16 nM
Compound 4: middle estimate off by 3.1-fold (0.49 log units), on the high side, and the stated range covers the measured number.
By their numbers in this assay, from the lowest: compounds 1, 3, 4 and 2 (each within the scatter of the next).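

Swapping the whole phenylsulfanyl group, aromatic ring included, for methoxy leaves the reading in this assay within the scatter: a 1.1-fold higher number from compound 3 to compound 4 (0.06 log units; within the scatter). The comparisons with the two chlorinated compounds agree, with a 1.2-fold lower number from compound 2 to compound 4 (0.07 log units; within the scatter) and a 1.1-fold higher number from compound 1 to compound 4 (0.06 log units; within the scatter), so among these four compounds the ring carried on sulfur is not needed for a number at this level, something the earlier steps could not show, as they only moved or removed a chloro on that ring and always kept the ring itself. Nothing available here explains why such different groups read alike at this position, ortho to a methylsulfonyl group.

As far as these compounds go, it remains open whether this tolerance extends to groups of another kind at the same position, such as a bare hydrogen, an amine like dimethylamino, a carboxylic acid or a longer chain like butoxy. From the compounds shown here alone, all four compounds also carry the same methylsulfonyl and methyl groups, so it is equally open whether the flat picture would hold with either of those replaced.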